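The source may report more compounds than this note shows. Statements on the series, on what has been measured and on what is new or still open speak of the compounds shown alone.

Measured compounds:
- compound 1 `COCC(=O)NC1CCN(c2nc(C)c3cc(NC(=O)/C=C/c4ccc(OC(F)(F)F)cc4)ccc3n2)CC1`, in an assay on CHO-K1 cells for displacement of a labelled ligand from melanin-concentrating hormone receptor 1 (Homo sapiens), read by scintillation proximity assay, with a stated time of 2 h (a lower number here means a stronger inhibitor, a higher number a weaker inhibitor), compound 1 gives 32 nM
- compound 2 `Cc1nc(N2CCC(N3CCNC3=O)CC2)nc2ccc(NC(=O)/C=C/c3ccc(OC(F)(F)F)cc3)cc12`, compound 2 gives 66 nM
- compound 3 `Cc1nc(N2CCC(N3C(=O)CCC3=O)CC2)nc2ccc(NC(=O)/C=C/c3ccc(OC(F)(F)F)cc3)cc12`, compound 3 gives 94 nM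

Compound 3 carries the highest number of the three. Its nearest neighbour is compound 2, with a 1.4-fold higher number from compound 2 to compound 3 (0.15 log units; within the scatter), a step within the scatter, so no order between compound 2 and compound 3 can be read. Against compound 1 the step is larger, a 2.9-fold higher number from compound 1 to compound 3 (0.47 log units; beyond the scatter), and compound 1 also stands apart from compound 2, a 2.1-fold higher number from compound 1 to compound 2 (0.31 log units; beyond the scatter).

Compound 4 `Cc1nc(N2CCC(N3CCN(C)C3=O)CC2)nc2ccc(NC(=O)/C=C/c3ccc(OC(F)(F)F)cc3)cc12` differs from compound 3 by 3-methyl-2-oxoimidazolidin-1-yl in place of 2,5-dioxopyrrolidin-1-yl on a saturated ring carbon. Going by the values given here, the step that bears on it directly is the exchange of the same five-membered ring position from compound 2 to compound 3, which stayed within the scatter; compound 4 carries the ring of compound 2 with a methyl on its second nitrogen, a change for which no measured pair exists. Both exchanges at this saturated ring carbon so far moved the number little compared with the step from compound 1. The expectation is therefore a step of a 1.3-fold lower number from compound 3 to compound 4 (0.13 log units; within the scatter), downward if anything, but not clearly beyond the scatter. Compound 4 is estimated at 70 nM, within 30 nM to 170 nM.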

Compound 4, half-maximal inhibitory concentration: 21 nM
Compound 4: middle estimate off by 3.3-fold (0.52 log units), on the high side; measured number outside the range, below it.
By their numbers in this assay, from the lowest: compounds 4 and 1 (each within the scatter of the next); then compounds 2 and 3 (each within the scatter of the next).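

In this assay, methyl in place of hydrogen on the amide-type nitrogen in the ring gives a 3.1-fold lower number from compound 2 to compound 4 (0.50 log units; beyond the scatter) and is the only change shown at that nitrogen, so a small addition to the group on the saturated ring carbon can move the number even though the exchange between compound 2 and compound 3 stayed within the scatter. The exchange of 2,5-dioxopyrrolidin-1-yl for 3-methyl-2-oxoimidazolidin-1-yl gives a 4.5-fold lower number from compound 3 to compound 4 (0.65 log units; beyond the scatter) while a 1.5-fold lower number from compound 1 to compound 4 (0.18 log units; within the scatter) gives no order between the cyclic group and the open ((methoxymethyl)carbonyl)amino group. No measurement at hand accounts for the effect of this methyl.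

As far as these compounds go, whether an ethyl group or a longer chain on that nitrogen would extend or reverse the step remains open. Also open, from the compounds shown here alone, is how a primary amine or a carboxylic acid on the saturated ring carbon would read in this assay.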